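From thiophen-2-yl to 4-methoxyphenyl: notes on compound 3

This account rests on a few compounds, and the source may have more. Where it says the series, first, only, none or still open, it means among the compounds named here.

Among the measured compounds shown here, only two compounds have results so far in a functional assay on NCI-H460 cells (Homo sapiens) for inhibition, read by MTT assay, with a stated time of 48 h; a lower number here means a stronger inhibitor, a higher number a weaker inhibitor. For the measured compounds named here, there, compound 1 `O=C(CC(c1ccc(F)cc1)C(C(=O)Nc1ccccn1)C(=O)Nc1ccccn1)c1ccc(F)cc1` gives 20100 nM, the only number available. Going by the values given here, compound 2 `O=C(CC(c1cccs1)C(C(=O)Nc1ccccn1)C(=O)Nc1ccccn1)c1ccccc1` is recorded as "not active" (no number reported), and no number accompanies that result, so it has no exact place on the scale and no step can be calculated from it.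

Compound 3 `COc1ccc(C(CC(=O)c2ccccc2)C(C(=O)Nc2ccccn2)C(=O)Nc2ccccn2)cc1` still awaits measurement in this assay. Among the compounds with values here, the single structural change is 4-methoxyphenyl in place of thiophen-2-yl on a saturated chain carbon bound to two saturated chain carbons. Within the data shown here, the data contain no measured pair that shows what this replacement does, so the expected size of the step in this assay cannot be fixed. The expected direction is from the no-number result towards a measurable but weak reading. Among the measured compounds shown here, the only anchor for that reading is compound 1 at 20100 nM. A second result without a number also remains possible. Compound 3 is expected at 30000 nM, with an estimated range of 10000 nM to 80000 nM.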

Compound 3, half-maximal inhibitory concentration: "not active" (no number reported)
No number was reported for compound 3; no gap can be computed for the estimate.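

In this assay compound 2 and compound 3 both stand as "not active" without a number, and no step can be read between them. No measured evidence bears on this result. The compounds shown leave open what the change from thiophen-2-yl to 4-methoxyphenyl does when both partners carry a numerical reading.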